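Thiophene-fused cores: swapping a pyrrolidine for a piperidine

A few compounds are considered here, and "the series" means these few. Any claim that something is new, unique, unknown or untested is made for them only; others in the source may bear on it.

Measured compounds in a functional assay on A549 cells (Homo sapiens) for inhibition, read by MTT assay, with a stated time of 72 h; a higher number here means a weaker inhibitor, a lower number a stronger inhibitor:
compound 1 `CN(c1ccc(Oc2ncnc3ccsc23)cc1)c1nccc(N2CCCC2)n1` gives 6510 nM
compound 2 `CN(c1ccc(Oc2ncnc3ccsc23)cc1)c1nccc(N2CCCCC2)n1` gives 8240 nM
compound 3 `CN(c1ccc(Oc2ncnc3sccc23)cc1)c1nccc(N2CCCC2)n1` gives 15100 nM

Compounds 1 and 2 share a core and differ by one change, (piperidin-1-yl in place of pyrrolidin-1-yl on an aromatic carbon). That change made a 1.3-fold higher number from compound 1 to compound 2 (0.10 log units; within the scatter). Compound 3 carries a different core from compound 1; the two cores have the same atoms joined differently, and how they differ is a group of 9 heavy atoms (6 carbon, 2 nitrogen, 1 sulfur; one five-membered aromatic ring with 1 hetero atom, one six-membered aromatic ring with 2 hetero atoms) in place of a group of 9 heavy atoms (6 carbon, 2 nitrogen, 1 sulfur; one five-membered aromatic ring with 1 hetero atom, one six-membered aromatic ring with 2 hetero atoms), on an oxygen on an aromatic ring. That core change made a 2.3-fold higher number from compound 1 to compound 3 (0.37 log units; beyond the scatter), so compound 3 sits at the high end of the three numbers.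

Compound 4 `CN(c1ccc(Oc2ncnc3sccc23)cc1)c1nccc(N2CCCCC2)n1` has not yet been measured in this assay. It stands to compound 3 as compound 2 stands to compound 1: the change is piperidin-1-yl in place of pyrrolidin-1-yl on an aromatic carbon, the same change that turned compound 1 into compound 2. Among the measured compounds shown here, since that earlier step was a 1.3-fold higher number from compound 1 to compound 2 (0.10 log units; within the scatter), the expectation is a similarly small step, a 1.3-fold higher number from compound 3 to compound 4 (0.10 log units; within the scatter), resting on the one matching pair available. Compound 4 is therefore estimated to give 19000 nM in this assay, with a range of 9000 nM to 40000 nM.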

Compound 4, half-maximal inhibitory concentration: 8790 nM
Compound 4: middle estimate off by 2.2-fold (0.33 log units), on the high side; measured number below the stated range.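

In this assay, piperidin-1-yl in place of pyrrolidin-1-yl on the core of compound 3 gave a 1.7-fold lower number from compound 3 to compound 4 (0.23 log units; within the scatter), and this step does not differ beyond the scatter from the same change on the core of compound 1: the same change on two cores in this assay, a 1.3-fold higher number (0.10 log units; within the scatter) from compound 1 to compound 2 and a 1.7-fold lower number (0.23 log units; within the scatter) from compound 3 to compound 4, 2.2-fold (0.34 log units) apart, within the scatter of two such steps. The core change made with piperidin-1-yl in place gave a 1.1-fold higher number from compound 2 to compound 4 (0.03 log units; within the scatter), and although it lay within the scatter here and beyond it with pyrrolidin-1-yl, the two steps do not differ beyond the scatter either: the same change on two cores in this assay, a 2.3-fold higher number (0.37 log units; beyond the scatter) from compound 1 to compound 3 and a 1.1-fold higher number (0.03 log units; within the scatter) from compound 2 to compound 4, 2.2-fold (0.34 log units) apart, within the scatter of two such steps. So nothing here shows that either change behaves differently from one partner to the other, but this is not proof that the effects carry over, as each comparison rests on a single pair of small steps.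

The compounds shown leave open how a morpholine or a dimethylamino group would fare at this place on either core. They also leave open whether a larger change there would give steps big enough to compare clearly between the two cores.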